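This account rests on a few compounds, and the source may have more. Where it says the series, first, only, none or still open, it means among the compounds named here.

Measured so far in a functional assay on MKN-74 cells (Homo sapiens) for antiproliferative activity, with a stated time of 24 h; on this read-out lower numbers stand for stronger inhibition and higher numbers for weaker inhibition:

Compound 1 `COc1ccccc1C(=O)Nc1sc2c(c1C(N)=O)CCN(C(=S)Nc1ccccc1Cl)C2` gives 20500 nM in this assay.
Compound 2 `CSc1ccccc1C(=O)Nc1sc2c(c1C(N)=O)CCN(C(=S)Nc1ccccc1Cl)C2` gives 6550 nM in this assay.

Among the measured compounds shown here, of these two numbers, compound 2 holds the lower one, and its only neighbour is compound 1. For the measured compounds named here, the single step between them, a 3.1-fold lower number from compound 1 to compound 2 (0.50 log units; beyond the scatter), came from putting methylsulfanyl in place of methoxy on an aromatic carbon; everything else in the two structures is the same.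

Compound 3 `NC(=O)c1c(NC(=O)c2ccncn2)sc2c1CCN(C(=S)Nc1ccccc1Cl)C2` is the next compound, not yet measured. It differs from compound 2 by pyrimidin-4-yl in place of 2-(methylsulfanyl)phenyl on a carbonyl carbon. Going by the values given here, this is a larger change than the one already seen: the whole ring attached to the carbonyl carbon is exchanged, and the methylsulfanyl group whose arrival gave the only measured step is gone with it. Among the compounds with values here, the one measured step therefore bears on the new change only loosely. It shows that what hangs on the carbonyl carbon can move the number by a modest amount; it does not show which way a wholly different ring will go. A step back toward weaker inhibition seems the safer expectation, since the group tied to the lower number is being removed.

Compound 3 is therefore expected to give about 15000 nM in this assay, within a range of 4000 nM to 60000 nM.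
This estimate amounts to an expected step of a 2.3-fold higher number from compound 2 to compound 3 (0.36 log units; beyond the scatter).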

Compound 3, half-maximal inhibitory concentration: 28400 nM
Compound 3: middle estimate off by 1.9-fold (0.28 log units), on the low side; the measured number falls inside the stated range.
By their numbers in this assay, from the lowest: compound 2; then compounds 1 and 3 (each within the scatter of the next).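

In this assay the whole ring on the carbonyl carbon can be exchanged, and the pyrimidin-4-yl ring of compound 3 does not keep the lower number that came with 2-(methylsulfanyl)phenyl (a 4.3-fold higher number from compound 2 to compound 3 (0.64 log units; beyond the scatter)). Set against the 2-methoxyphenyl ring, the same pyrimidin-4-yl ring makes no readable difference (a 1.4-fold higher number from compound 1 to compound 3 (0.14 log units; within the scatter)), so among the three rings shown, only 2-(methylsulfanyl)phenyl stands apart from the other two. No accompanying measurement says why these ring changes act as they do.

On these data alone, it remains open whether an aromatic ring is needed on this carbonyl carbon at all, or whether a saturated ring such as cyclohexyl or a plain chain such as propyl would serve there with the rest of the molecule unchanged. As far as these compounds go, it is also open whether methylsulfanyl would give a lower number on a ring other than phenyl, for example on a pyridine ring, or whether a larger group such as ethylsulfanyl would move the number further from that of compound 2.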